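A Bromo-to-Chloro Swap in a Flat Series

The source may hold more compounds than are shown below. What is called first, only, known or untested is meant among the compounds shown, and "the series" means these compounds.

In a functional assay on HL-60 cells (Homo sapiens) for cytotoxicity, read by CCK-8 assay, with a stated time of 24 h (a lower number here means a stronger inhibitor, a higher number a weaker inhibitor), compound 1 (`C=CC(=O)N1C(=O)CC(c2ccc(C(F)(F)F)cc2)Sc2ccccc21`) gives 106000 nM and compound 2 (`C=CC(=O)N1C(=O)CC(c2ccc(OC)cc2)Sc2ccccc21`) gives 92100 nM while compound 3 (`C=CC(=O)N1C(=O)CC(c2ccc(Br)cc2)Sc2ccccc21`) gives 126000 nM in the same narrow band. Compound 3 therefore stands level with the other two. Among the measured compounds shown here, the swaps measured so far moved little: the series shows a 1.2-fold lower number from compound 1 to compound 2 (0.06 log units; within the scatter) and a 1.2-fold higher number from compound 1 to compound 3 (0.08 log units; within the scatter) and a 1.4-fold higher number from compound 2 to compound 3 (0.14 log units; within the scatter) as its only steps. Compound 4 (`C=CC(=O)N1C(=O)CC(c2ccc(Cl)cc2)Sc2ccccc21`) differs from compound 3 by one swap (chloro in place of bromo on an aromatic carbon) with chloro in place of bromo on an aromatic carbon. The expected result is a 1.1-fold lower number from compound 3 to compound 4 (0.06 log units; within the scatter) and so no real shift is anticipated in this assay here. For compound 4 the estimated value is 110000 nM with an expected range from 70000 nM to 170000 nM overall.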

Compound 4, half-maximal inhibitory concentration: 95700 nM
For compound 4 the middle estimate is 1.1-fold (0.06 log units) above the measured one; the range from low to high includes it.
By their numbers in this assay, from the lowest: compounds 2, 4, 1 and 3 (each within the scatter of the next).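

In this assay, the step from bromo to chloro gives a 1.3-fold lower number from compound 3 to compound 4 (0.12 log units; within the scatter) and adds a fourth group to the same narrow band at this place, para to a large group. Chloro also stands level with methoxy, at a 1.0-fold higher number from compound 2 to compound 4 (0.02 log units; within the scatter) and with trifluoromethyl, at a 1.1-fold lower number from compound 1 to compound 4 (0.04 log units; within the scatter) and so none of the four groups stands apart here. No available evidence bears on why these groups read alike. On these data alone, it remains open whether an amine or a carboxylic acid at this place would stay in the band. Changes elsewhere on the shared core also remain open.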